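A few compounds are considered here, and "the series" means these few. Any claim that something is new, unique, unknown or untested is made for them only; others in the source may bear on it.

In a functional assay on KB cells (Homo sapiens), read by MTT assay (a lower number here means a stronger inhibitor, a higher number a weaker inhibitor), compound 1, whose structure is `C#C[C@@]1(O)[C@H](O)[C@@H](CO)O[C@H]1n1ccc(N)nc1=O`, gives only a limit, > 350000 nM. Compound 2, with the structure `C#C[C@@H]1[C@@H](O)[C@H](n2ccc(N)nc2=O)O[C@@H]1CO`, likewise gives only a limit in this assay, > 350000 nM. Compound 3, built as `O=c1ccn([C@@H]2O[C@H](CO)[C@](O)(C3CC3)[C@H]2O)c(=O)[nH]1`, also reaches no more than a limit in this assay, > 350000 nM. Compound 3 therefore stands where every value shown stands, at the limit of > 350000 nM in this assay, at which 3 of the 3 values shown sit, so no ordering among the three can be drawn. Compound 4, with the structure `C=C[C@@]1(O)[C@@H](CO)O[C@@H](n2ccc(=O)[nH]c2=O)[C@@H]1O`, differs from compound 3 by vinyl in place of cyclopropyl on a saturated ring carbon. Within the data shown here, with no measured step available, no direction can be inferred; compound 4 is expected to remain near the limit, a step that the limit leaves unreadable from compound 3 to compound 4 within the scatter. The estimate for compound 4 in this assay is 400000 nM, between 100000 nM and 1500000 nM.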

Compound 4, half-maximal inhibitory concentration: 51800 nM
For compound 4 the middle estimate is 7.7-fold (0.89 log units) above the measured one; measured number below the stated range.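

In this assay, among these compounds, vinyl in place of cyclopropyl on a saturated ring carbon gives an at least 6.7-fold lower number from compound 3 to compound 4 (0.82 log units; beyond the scatter), the first sign that a change at this position can move the read-out away from the limit. Compound 4 is the only compound shown with a measured number rather than a limit: the limit of > 350000 nM in this assay, at which 3 of the 4 values shown sit.

As far as these compounds go, the full size of the step stays open, as the starting point of compound 3 is only a limit. Also open, from the compounds shown here alone, is how an ethyl group at this carbon would read in this assay, and whether the double bond of vinyl or the loss of the three-membered ring matters.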